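The source may hold more compounds than are shown below. What is called first, only, known or untested is meant among the compounds shown, and "the series" means these compounds.

Compound 1 `O=C1C=CC2(C=C1)OCC(=O)N2S(=O)(=O)c1ccccc1`: > 10000 nM, a limit
Compound 2 `O=C1C=CC2(C=C1)OCC(=O)N2S(=O)(=O)c1ccc([N+](=O)[O-])cc1`: > 10000 nM, a limit
Compound 3 `O=C1C=CC2(C=C1)OCC(=O)N2S(=O)(=O)c1ccc(C(F)(F)F)cc1`: 770 nM

In a functional assay on HeLa cells (Homo sapiens) for inhibition, read by sulforhodamine B assay, with a stated time of 74 h (on this read-out lower numbers stand for stronger inhibition and higher numbers for weaker inhibition), compound 1 gives only a limit, > 10000 nM. Compound 1 therefore stands at the limit of > 10000 nM in this assay, at which 2 of the 3 values shown sit, and no exact starting number is available.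

Compound 4 `O=C1C=CC2(C=C1)OCC(=O)N2S(=O)(=O)c1ccc(Br)s1` keeps the shared core and changes the group on the sulfonyl sulfur: 5-bromothiophen-2-yl in place of phenyl (5-bromothiophen-2-yl in place of phenyl on a sulfonyl sulfur).

Two measured steps change that same aromatic group, although each adds a group to it and neither replaces the ring. Going by the values given here, the first is a step that the two limits leave unreadable from compound 1 to compound 2, so it gives no size. The second is an at least 12-fold lower number from compound 1 to compound 3 (1.11 log units; beyond the scatter), which shows that a change here can matter greatly. Compound 2 stays at the limit, however, so a new group does not always yield a measurable number.

Resting on the large step to compound 3, a clear drop is expected, though its size is uncertain. The expected step is an at least 10-fold lower number from compound 1 to compound 4 (1.00 log units; beyond the scatter). For compound 4 the estimated value is 1000 nM, with an expected range of 200 nM to 8000 nM.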

Compound 4, half-maximal inhibitory concentration: 30 nM
The estimate for compound 4 lay 33-fold (1.52 log units) above the measured number; measured number outside the range, below it.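

Until now, every change at this position kept the phenyl ring and added a group to it. Compound 4 shows that the ring on the sulfonyl sulfur can itself be replaced, and in this assay this replacement gives an at least 330-fold lower number from compound 1 to compound 4 (2.52 log units; beyond the scatter), even though phenyl and 5-bromothiophen-2-yl have the same count of heavy atoms. Compound 1 gives > 10000 nM, which is a limit, so the full size of this step cannot be read: the limit of > 10000 nM in this assay, at which 2 of the 4 values shown sit.

Compound 4 brings in a new ring and a bromine together, so the compounds shown cannot tell which of the two accounts for the step; a plain thiophen-2-yl group and a phenyl group carrying bromine would separate them. Also open, from the compounds shown here alone, is how a thiophene ring carrying an amine or a carboxylic acid in place of bromine would behave.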